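Chloro for fluoro on two cores: cytotoxicity notes

A few compounds are considered here, and "the series" means these few. Any claim that something is new, unique, unknown or untested is made for them only; others in the source may bear on it.

Measured so far in an ADME assay on MT2 cells (Homo sapiens) for cytotoxicity, read by MTT assay; on this read-out higher numbers stand for lower toxicity in this test and lower numbers for higher toxicity in this test:
compound 1 `N#Cc1ccc2c(Oc3ccc(F)cc3OCCn3ccc(=O)[nH]c3=O)cc(Cl)cc2c1`: 16000 nM
compound 2 `N#Cc1ccc2c(Oc3ccc(F)cc3OCCn3ccc(=O)[nH]c3=O)cc(F)cc2c1`: a limit, > 100000 nM
compound 3 `N#Cc1cc2c(Oc3ccc(F)cc3OCCn3ccc(=O)[nH]c3=O)cc(F)cn2c1`: 50000 nM

Compound 2 stands at a limit of this assay and not at a number; it sits at the limit of > 100000 nM in this assay, at which 1 of the 3 values shown sits. The step from compound 2 to compound 1 is chloro in place of fluoro on an aromatic carbon, and it gave an at least 6.2-fold lower number from compound 2 to compound 1 (0.79 log units; beyond the scatter). Compound 3 carries a second core; the difference between the two cores is not broken down here. Compound 3 gives the highest number of the two that are numbers, with compound 1 nearest.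

Compound 4 `N#Cc1cc2c(Oc3ccc(F)cc3OCCn3ccc(=O)[nH]c3=O)cc(Cl)cn2c1` is not yet measured in this assay. It differs from compound 3 by chloro in place of fluoro on an aromatic carbon: the same kind of change as from compound 2 to compound 1, though here the ring holds one nitrogen and the carbon sits two atoms from the ring nitrogen, where in compound 1 the ring is of carbon only. On the strength of the step from compound 2 to compound 1, compound 4 is expected to give a 5.0-fold lower number from compound 3 to compound 4 (0.70 log units; beyond the scatter). Compound 4 is estimated at 10000 nM, between 3000 nM and 35000 nM.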

Compound 4, half-maximal cytotoxic concentration: 15000 nM
The estimate for compound 4 lay 1.5-fold (0.18 log units) below the measured number; measured number inside the range.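

In this assay, chloro in place of fluoro on an aromatic carbon, here on the ring with one nitrogen, again gives a change in the same direction, a 3.3-fold lower number from compound 3 to compound 4 (0.52 log units; beyond the scatter). The direction thus carries over between the two cores shown, with the earlier step being an at least 6.2-fold lower number from compound 2 to compound 1 (0.79 log units; beyond the scatter), and the comparison of the two stands as follows: the same change on two cores in this assay, an at least 6.2-fold lower number (0.79 log units; beyond the scatter) from compound 2 to compound 1 and a 3.3-fold lower number (0.52 log units; beyond the scatter) from compound 3 to compound 4; the limit leaves it open whether they differ. This rests on two pairs only, and compound 2 stands at a limit, so the series shows no size of change that carries from one core to the other and no rule for any further core: the limit of > 100000 nM in this assay, at which 1 of the 4 values shown sits.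

On these data alone, only fluoro and chloro appear at this aromatic carbon, so it remains open how a bromo, methyl or methoxy group there would read in this assay. As far as these compounds go, whether the step would hold with a carboxylic acid in place of the nitrile is equally open.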